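Compound 2 to compound 4: a trimethoxyphenyl replacement

This account rests on a few compounds, and the source may have more. Where it says the series, first, only, none or still open, it means among the compounds named here.

In a functional assay on HCT-116 cells (Homo sapiens) for inhibition, read by sulforhodamine B assay, with a stated time of 48 h, tested at 50 uM (on this read-out lower numbers stand for less inhibition of growth and higher numbers for more inhibition of growth at the one concentration tested), compound 2 `COc1cccc(/C=C/C(=O)/C=C/c2ccc(OCc3cn(CCCOc4cc(=O)oc5ccccc45)nn3)c(OC)c2)c1` gives 55%. Compound 1 `COc1ccccc1/C=C/C(=O)/C=C/c1ccc(OCc2cn(CCCOc3cc(=O)oc4ccccc34)nn2)c(OC)c1` gives 53%, within the scatter of compound 2, so these two sit together at the upper end of the three numbers. Compound 3 `COc1ccccc1/C=C/C(=O)/C=C/c1ccc(OCc2cn(CCCCOc3cc(=O)oc4ccccc34)nn2)c(OC)c1`, at 43%, lies lower than compound 2 by more than the scatter.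

The next compound is compound 4 `COc1cc(/C=C/C(=O)/C=C/c2cc(OC)c(OC)c(OC)c2)ccc1OCc1cn(CCCOc2cc(=O)oc3ccccc23)nn1`. Its change is 3,4,5-trimethoxyphenyl in place of 3-methoxyphenyl on a double-bonded chain carbon bound to a double-bonded chain carbon.

For the measured compounds named here, only one measured step touches this group: a number 2 percentage points higher from compound 1 to compound 2 (within the scatter). It is small, but it only swaps one methoxyphenyl group for another. Going by the values given here, no measured compound carries the 3,4,5-trimethoxyphenyl group, so the series gives weak guidance here and the range stays wide.

The estimated step is no change at the digits printed from compound 2 to compound 4 (within the scatter), with no shift beyond the scatter expected. For compound 4 the expected value is 55%, with an estimated range of 40% to 70%.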

Compound 4, percent growth inhibition at one concentration: 76%
Estimate against measurement, compound 4: 21 percentage points below; the whole stated range lies below it.
By their numbers in this assay, from the lowest: compounds 3, 1 and 2 (each within the scatter of the next, the first and the last beyond it); then compound 4.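

In this assay this position on a double-bonded chain carbon bound to a double-bonded chain carbon proves responsive: 3,4,5-trimethoxyphenyl gives a number 21 percentage points higher from compound 2 to compound 4 (beyond the scatter), and against the 2-methoxyphenyl group it gives a number 23 percentage points higher from compound 1 to compound 4 (beyond the scatter). The earlier swap between the two methoxyphenyl groups, a number 2 percentage points higher from compound 1 to compound 2 (within the scatter), showed no such sensitivity, so the position's effect on growth inhibition appears only with the 3,4,5-trimethoxyphenyl group. No available measurement bears on the reason for this gain.

The compounds shown leave open whether all three methoxy groups are needed, or whether a 4-methoxyphenyl or 3,4-dimethoxyphenyl group would match 3,4,5-trimethoxyphenyl. They also leave open whether the gain carries over to the chain of compound 3, and whether a hydroxyl or fluorine substituent on this ring would retain it.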